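Dropping a Nitro Group: Expectation for Compound 4

This account rests on a few compounds, and the source may have more. Where it says the series, first, only, none or still open, it means among the compounds named here.

In a functional assay on KYSE-450 cells (Homo sapiens) for inhibition, read by MTT assay, with a stated time of 48 h (a lower number here means a stronger inhibitor, a higher number a weaker inhibitor), compound 2 `COc1ccc(CNc2cc(OC)c(OC)c(OC)c2)cc1[N+](=O)[O-]` gives 16800 nM and stands second highest of three numbers. Its nearest neighbour is compound 3 `COc1ccc(N(Cc2cc(OC)c(OC)c(OC)c2)C(=O)CCl)cc1O` with 29800 nM in the same assay, a gap within the scatter, while compound 1 `C/C=C/C(=O)N(Cc1ccc(OC)c([N+](=O)[O-])c1)c1cc(OC)c(OC)c(OC)c1` with 510 nM lies furthest away. For the measured compounds named here, the single measured step, a 33-fold higher number from compound 1 to compound 2 (1.52 log units; beyond the scatter) in this assay, concerns the nitrogen on the aromatic ring and does not bear on the change now considered. Compound 4 `COc1ccc(CNc2cc(OC)c(OC)c(OC)c2)cc1` differs from compound 2 by hydrogen in place of nitro on an aromatic carbon on the ring. Going by the values given here, no measured pair addresses this change directly, though compound 3 also carries no nitro group and sits within the scatter of compound 2. A step of no size beyond the scatter is therefore expected, a 1.2-fold higher number from compound 2 to compound 4 (0.08 log units; within the scatter) in this assay. Compound 4 is expected to give about 20000 nM in this assay, between 6000 nM and 60000 nM as the likely range.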

Compound 4, half-maximal inhibitory concentration: 4890 nM
Compound 4: middle estimate off by 4.1-fold (0.61 log units), on the high side; the whole stated range lies above it.
By their numbers in this assay, from the lowest: compound 1; then compound 4; then compounds 2 and 3 (each within the scatter of the next).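

Replacing the nitro group with hydrogen on this aromatic carbon, ortho to a methoxy group, gives a 3.4-fold lower number from compound 2 to compound 4 (0.54 log units; beyond the scatter) in this assay and so marks this position as one where a change matters. The earlier step concerned only the nitrogen, whereas this pair shows that the nitro group is not needed for the activity of compound 4. Nothing shown explains this step. Going by these compounds, whether an amine or a fluorine atom on this carbon would raise or lower the number remains open. Also open, on these data alone, is whether losing the nitro group has the same effect when the nitrogen carries the (prop-1-en-1-yl)carbonyl of compound 1.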